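This account rests on a few compounds, and the source may have more. Where it says the series, first, only, none or still open, it means among the compounds named here.

Compound 1 `O=C1CCCN1c1cccc(C(=O)N(c2ncccc2Cl)[C@@H]2CCCNC2)c1` and compound 2 `O=C1CCCCN1c1cccc(C(=O)N(c2ncccc2Cl)[C@@H]2CCCNC2)c1` share one core and differ at a single spot. In a physicochemical assay for solubility, at pH 7.4 (on this read-out lower numbers stand for lower solubility and higher numbers for higher solubility), compound 1 gives 67000 nM. For compound 2 this assay reports only a limit, > 973000 nM. The change between the two is 2-oxopiperidin-1-yl in place of 2-oxopyrrolidin-1-yl on an aromatic carbon, and it made an at least 14-fold higher number from compound 1 to compound 2 (1.16 log units; beyond the scatter), a step whose size rests on the limit of > 973000 nM in this assay, at which 1 of the 3 values shown sits, rather than on a measured number. Compound 3 `O=C([C@@H]1C[C@H]1c1cccc(N2CCCC2=O)c1)N1CCN(C2CCC2)CC1` is built on a different core; how the two cores differ is not broken down here. For compound 3 this assay gives only a limit, > 4130000 nM. Compound 4 `O=C([C@@H]1C[C@H]1c1cccc(N2CCCCC2=O)c1)N1CCN(C2CCC2)CC1` has not yet been measured in this assay. It differs from compound 3 by 2-oxopiperidin-1-yl in place of 2-oxopyrrolidin-1-yl on an aromatic carbon, the same change as from compound 1 to compound 2, at the same kind of place. Because compound 3 already sits at the limit of > 4130000 nM in this assay, at which 1 of the 3 values shown sits, any number for compound 4 is expected to come out at or past that limit, and the step is estimated as a step that the limit leaves unreadable from compound 3 to compound 4, which can only be a guess since the starting point is itself a limit. On that footing compound 4 is expected to show about 5000000 nM, with a range from 3000000 nM to 10000000 nM, and most likely the report will again be a limit rather than a number.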

Compound 4, solubility: > 3000000 nM
Compound 4: no number, only a limit; the forecaster's own chance of this, stated with the estimate: 80%; the middle value is on the limit's open side.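

In this assay compound 3 and compound 4 each give only a limit rather than a number, and the step between them cannot be read. The compounds shown leave open where the true values of compound 3 and compound 4 lie, and whether 2-oxopiperidin-1-yl in place of 2-oxopyrrolidin-1-yl changes the read-out on the core of compound 3 at all.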